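Cyano for ethoxy on the benzamide ring of compound 1

The source may hold more compounds than are shown below. What is called first, only, known or untested is meant among the compounds shown, and "the series" means these compounds.

Measured so far:
compound 1 `CCOc1ccc(C(=O)Nc2cc(Br)cc3c(=O)cc(C(=O)O)oc23)cc1` gives 1360 nM
compound 2 `CCCOc1ccc(C(=O)Nc2cccc3c(=O)cc(C(=O)O)oc23)cc1` gives 3610 nM
compound 3 `COc1ccc(C(=O)Nc2cccc3c(=O)cc(C(=O)O)oc23)cc1` gives 2160 nM

All three were measured in an assay on CHO cells for agonist activity at G protein-coupled receptor GPR35 (Rattus norvegicus), read by a beta-galactosidase reporter and beta-arrestin recruitment, with a stated time of 90 min; a higher number here means that more compound is needed for the effect, a lower number that less compound is needed. Compound 1 has the lowest of the three numbers; its nearest neighbour is compound 3, and its step to compound 3 lies within the scatter, while its step to compound 2 lies beyond it. Within the data shown here, the only one-place step among the measured compounds is a 1.7-fold lower number from compound 2 to compound 3 (0.22 log units; within the scatter), so the length of the alkoxy chain changes the number little.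

Compound 4 `N#Cc1ccc(C(=O)Nc2cc(Br)cc3c(=O)cc(C(=O)O)oc23)cc1` differs from compound 1 in one place: cyano in place of ethoxy on an aromatic carbon. Among the measured compounds shown here, no measured step touches a cyano group, and the one step available concerns only the chain on the oxygen, which stayed within the scatter. Nothing here supports a step in either direction, so compound 4 is expected to stay near compound 1, as a 1.1-fold higher number from compound 1 to compound 4 (0.04 log units; within the scatter). In this assay compound 4 is estimated at 1500 nM, with a range from 500 nM to 4500 nM.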

Compound 4, half-maximal effective concentration: 2260 nM
The estimate for compound 4 lay 1.5-fold (0.18 log units) below the measured number; the range from low to high includes it.
By their numbers in this assay, from the lowest: compounds 1, 3, 4 and 2 (each within the scatter of the next, the first and the last beyond it).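

Cyano in place of ethoxy on the aromatic carbon para to a large group gives, in this assay, a 1.7-fold higher number from compound 1 to compound 4 (0.22 log units; within the scatter) and so does not separate the two groups. Earlier compounds changed only the chain on the oxygen, whereas compound 4 shows that the number stays within the scatter of compound 1 when the oxygen and the chain are both gone and a triple bond enters. Nothing measured on these compounds accounts for this result.

Going by these compounds, it remains open whether the exchange of 4-ethoxyphenyl for 4-cyanophenyl would give a similar step on a core without the bromine of compound 1. On these data alone, the standing of an amine, a carboxylic acid or a butoxy chain at this position relative to compound 1 also remains open.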